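Cyanothiophene swap on the heteroaryl methyl ether series

The source may report more compounds than this note shows. Statements on the series, on what has been measured and on what is new or still open speak of the compounds shown alone.

- compound 1 (`O=C(COCc1ccncn1)N1CCN(c2ccc(Cl)cc2Cl)CC1`) gives 17 mL.min-1.g-1 in an in vitro ADME assay on microsomes from liver (Homo sapiens) for metabolic stability; on this read-out higher numbers stand for fast clearance and lower numbers for slow clearance
- compound 2 (`O=C(COCc1cscn1)N1CCN(c2ccc(Cl)cc2Cl)CC1`) gives 62 mL.min-1.g-1 in this assay
- compound 3 (`N#Cc1ccc(COCC(=O)N2CCN(c3ccc(Cl)cc3Cl)CC2)s1`) is still unmeasured

Compound 2 holds the higher of the two numbers, and compound 1 lies beyond the scatter below it. Compound 3 carries 5-cyanothiophen-2-yl in place of 1,3-thiazol-4-yl on a saturated chain carbon bound to an oxygen on a saturated carbon. Among the compounds with values here, one measured step bears on this change, taken at the same place, and it is modest (a 3.6-fold higher number from compound 1 to compound 2 (0.56 log units; beyond the scatter)). A single step sets no rule for the new group. Both compound 2 and compound 3 carry a five-membered aromatic ring, so a shift smaller than that modest step is expected, leaning slightly upward in this assay and probably within the scatter. The expected size is small (a 1.1-fold higher number from compound 2 to compound 3 (0.05 log units; within the scatter)). Compound 3 is expected at 70 mL.min-1.g-1 with 30 mL.min-1.g-1 to 160 mL.min-1.g-1 as the estimated range.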

Compound 3, intrinsic clearance in microsomes: 110 mL.min-1.g-1
Compound 3: middle estimate off by 1.6-fold (0.20 log units), on the low side; the range from low to high includes it.
By their numbers in this assay, from the lowest: compound 1; then compounds 2 and 3 (each within the scatter of the next).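

In this assay, 5-cyanothiophen-2-yl in place of 1,3-thiazol-4-yl on a saturated chain carbon bound to an oxygen on a saturated carbon gives a 1.8-fold higher number from compound 2 to compound 3 (0.25 log units; within the scatter), so this read-out does not separate the two groups, even with the added nitrile and one hetero atom fewer in the ring. Set against pyrimidin-4-yl at the same place, the new group gives a 6.5-fold higher number from compound 1 to compound 3 (0.81 log units; beyond the scatter), so two different five-membered aromatic rings now lie beyond the scatter from compound 1, a pattern that rests on these three compounds alone. No measured evidence accounts for either step.

Still open, from the compounds shown here alone, is how a plain thiophen-2-yl would read against 5-cyanothiophen-2-yl, which would separate the nitrile from the ring. Also open, going by these compounds, is where a pyridin-2-yl group at this place would fall relative to pyrimidin-4-yl.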